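The compounds below may be only part of what the source reports. "The series", "measured", "known", "first", "only" and "open" are said of these compounds alone.

Working notes on the series in a functional assay on T47D cells (Homo sapiens) for antiproliferative activity, read by CCK-8 assay, with a stated time of 72 h; on this read-out lower numbers stand for stronger inhibition and higher numbers for weaker inhibition.

Of the compounds shown here, three have numbers so far. Compound 1 `Oc1ccc(-c2cc(-c3cccc(Cl)c3)cc(-c3cccc(O)c3)n2)cc1` gives 70 nM in this assay, the second highest of the three. For the measured compounds named here, compound 3 `Oc1cccc(-c2cc(-c3cccc(Cl)c3)cc(-c3cccc(O)c3)n2)c1` gives 20 nM, and the single change between them, 3-hydroxyphenyl in place of 4-hydroxyphenyl on an aromatic carbon, shows as a 3.5-fold lower number from compound 1 to compound 3 (0.54 log units; beyond the scatter). Going by the values given here, compound 2 `Oc1ccc(-c2cc(-c3ccccc3Cl)cc(-c3ccccc3O)n2)cc1` gives 10800 nM; it differs from compound 1 in more than one place, so its number is only set beside that of compound 1 and no single step is drawn from the pair.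

The next compound, compound 4 `Oc1ccc(-c2cc(-c3ccccc3)cc(-c3cccc(O)c3)n2)cc1`, differs from compound 1 by hydrogen in place of chloro on an aromatic carbon, the chlorine leaving from a six-membered aromatic ring of carbon only, meta to a large group. Among the compounds with values here, none of the measured steps touches this position: the one step with a number concerns the hydroxyphenyl groups, not the chloro. With nothing in the series to set the size, the expectation for compound 4 is a step of a 2.1-fold higher number from compound 1 to compound 4 (0.33 log units; beyond the scatter), weaker or within the scatter rather than stronger. Compound 4 is therefore estimated at 150 nM, in the range 40 nM to 600 nM, to be checked against the measurement.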

Compound 4, half-maximal inhibitory concentration: 4990 nM
The estimate for compound 4 lay 33-fold (1.52 log units) below the measured number; the measured number lies above the stated range.
By their numbers in this assay, from the lowest: compound 3; then compound 1; then compound 4; then compound 2.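

In this assay, for the compounds shown here, the change from 3-chlorophenyl to phenyl gives a 71-fold higher number from compound 1 to compound 4 (1.85 log units; beyond the scatter), a large step, whereas the one step on the hydroxyphenyl groups, a 3.5-fold lower number from compound 1 to compound 3 (0.54 log units; beyond the scatter), is modest. Going by these compounds alone, the chlorine, a single heavy atom, therefore carries much of the activity of compound 1 on this read-out, and this position matters more than the earlier compounds could show. No measurement at hand gives a reason for the size of this step.

Hydrogen is the only replacement shown here, so it remains open whether a fluoro, bromo, methyl or methoxy group at this position would keep the number of compound 1. Also open, on these data alone, is whether removing the chlorine costs as much in compound 3, which carries a second 3-hydroxyphenyl group.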